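The source may hold more compounds than are shown below. What is called first, only, known or untested is meant among the compounds shown, and "the series" means these compounds.

Compound 2 `CCc1cc(C(C)=O)c(O)cc1OCCCC(C)(C)c1nnn[nH]1` stands highest of the two numbers in an assay on isolated protein for binding affinity to leukotriene B4 receptor 1 (Homo sapiens), tested at 1 uM (a lower number here means less inhibition, a higher number more inhibition at the concentration tested (going by the name of the read-out)), where compound 2 gives 76%; its nearest neighbour is compound 1 `CCc1cc(C(C)=O)c(O)cc1OCCCCCCC#N`, which gives 73%, and the step of a number 3 percentage points higher from compound 1 to compound 2 (within the scatter) lies within the scatter. Compound 3 `CCc1cc(C(C)=O)c(O)cc1OCCCCCC[S+](C)[O-]` carries a group of 6 heavy atoms (4 carbon, 1 oxygen, 1 sulfur; no ring) in place of a group of 8 heavy atoms (4 carbon, 4 nitrogen; one five-membered aromatic ring with 4 hetero atoms), on a saturated chain carbon, three bonds along the chain from an oxygen on an aromatic ring. Within the data shown here, no measured step matches this exchange; the only one at hand, at the same place on a saturated chain carbon three bonds along the chain from an oxygen on an aromatic ring, stayed within the scatter, so the step of a number 6 percentage points lower from compound 2 to compound 3 (within the scatter) is expected to be small, with no direction beyond the scatter. Compound 3 is therefore estimated at 70%, between 55% and 85%.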

Compound 3, a percentage reported as inhibition, at one concentration (the size of the read-out at that concentration, not a potency): 50%
Compound 3: middle estimate off by 20 percentage points, on the high side, outside the stated range (below it).
By their numbers in this assay, from the lowest: compound 3; then compounds 1 and 2 (each within the scatter of the next).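

In this assay the chain end proves sensitive to what it carries, a point the earlier exchange of 3-cyanopropyl for 1-(1H-tetrazol-5-yl)-1-methylethyl did not reveal. The sulfur- and oxygen-bearing group gives a step of a number 26 percentage points lower from compound 2 to compound 3 (beyond the scatter) and likewise a step of a number 23 percentage points lower from compound 1 to compound 3 (beyond the scatter) so it falls short of both the tetrazole and the nitrile. Nothing at hand accounts for this loss. As far as these compounds go, whether a carboxylic acid or an amine at this place would keep the higher level remains open. So does whether a longer chain would restore it to the sulfur-bearing group.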